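Swapping an Acid Tail for a Hydroxamic Acid

The source may hold more compounds than are shown below. What is called first, only, known or untested is meant among the compounds shown, and "the series" means these compounds.

Four compounds share a urea core built on a substituted cyclohexane. Compound 1 `CC(C)c1ccc(NC(=O)N(Cc2ccc(C(=O)NCCC(=O)O)cc2)[C@H]2CC[C@H](C(C)(C)C)CC2)cc1` reaches 35 nM in an in vitro assay on BHK cells for inhibition of Glucagon receptor (Homo sapiens) (on this read-out lower numbers stand for stronger inhibition and higher numbers for weaker inhibition), and compound 2 `CCCC1CCC(N(Cc2ccc(C(=O)NCCC(=O)O)cc2)C(=O)Nc2ccc(OC(F)(F)F)cc2)CC1` gives 122 nM. From the compounds shown here alone, compound 3 `CC(C)(C)C1CCC(N(Cc2ccc(C(=O)NCCCC(=O)O)cc2)C(=O)Nc2ccc(OC(F)(F)F)cc2)CC1` returns only a limit of the assay, > 10000 nM, which is the limit of > 10000 nM in this assay, at which 1 of the 3 values shown sits, so its true value is unknown. Compound 4 `CC(C)(C)C1CCC(N(Cc2ccc(C(=O)NCC(=O)NO)cc2)C(=O)Nc2ccc(OC(F)(F)F)cc2)CC1` differs from compound 3 by hydroxycarbamoyl in place of 2-carboxyethyl on a saturated chain carbon bound to an amide-type nitrogen. Going by the values given here, no measured pair shows this change, so the expectation rests on compound 3 alone. The step from compound 3 to compound 4 is expected to be an at least 2.5-fold lower number from compound 3 to compound 4 (0.39 log units; beyond the scatter), toward stronger inhibition, yet uncertain. Compound 4 is estimated at 4000 nM, within a range of 400 nM to 40000 nM.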

Compound 4, half-maximal inhibitory concentration: 2960 nM
The estimate for compound 4 lay 1.4-fold (0.13 log units) above the measured number; the range from low to high includes it.
By their numbers in this assay, from the lowest: compound 1; then compound 2; then compound 4. At a limit, above all of these: compound 3.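

In this assay, the change in the tail gives an at least 3.3-fold lower number from compound 3 to compound 4 (0.52 log units; beyond the scatter). On this shared core, the tail position can therefore carry a group that yields a real number: compound 4 gives 2960 nM. Compound 3 stands at a limit of the assay, so the step gives only a minimum size: the limit of > 10000 nM in this assay, at which 1 of the 4 values shown sits.

The change replaces the end group and shortens the chain together, and the compounds shown do not separate these two parts. From the compounds shown here alone, how a methyl ester or a primary amide would read at this place also stays open.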